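This account rests on a few compounds, and the source may have more. Where it says the series, first, only, none or still open, it means among the compounds named here.

Measured so far in a functional assay on HCT-116 cells (Homo sapiens) for antiproliferative activity, read by CCK-8 assay, with a stated time of 72 h, tested at 2 uM; a higher number here means a stronger effect of the compound at the concentration tested, a lower number a weaker effect:
compound 1 `CC1CCN(c2nc(Cl)nc3c2ncn3Cc2ccc(/C=C/C(=O)Nc3ccccc3N)cc2)CC1`: 4.24%
compound 2 `Cc1ccc(Nc2nc(Cl)nc3c2ncn3Cc2ccc(/C=C/C(=O)Nc3ccccc3N)cc2)cc1`: 0.27%

Compound 2 and compound 1 lie within the scatter of each other, both giving only small inhibition at this concentration. Compound 3 `Nc1ccccc1NC(=O)/C=C/c1ccc(Cn2cnc3c(Nc4cccc(Cl)c4)nc(Cl)nc32)cc1` differs from compound 2 by 3-chlorophenyl in place of 4-methylphenyl on a nitrogen on an aromatic ring. For the measured compounds named here, the one measured step, a number 4 percentage points lower from compound 1 to compound 2 (within the scatter), exchanged the whole group on that aromatic carbon and stayed within the scatter; no step varies the substituent within the (4-methylphenyl)amino group, so it bears only loosely here. The expected step is therefore a number 2.7 percentage points higher from compound 2 to compound 3 (within the scatter), none beyond the scatter. Compound 3 is estimated at 3%, range 0% to 12%.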

Compound 3, a percentage reported as inhibition, at one concentration (the size of the read-out at that concentration, not a potency): 12.9%
For compound 3 the middle estimate is 9.9 percentage points below the measured one; measured number outside the range, above it.
By their numbers in this assay, from the lowest: compounds 2, 1 and 3 (each within the scatter of the next, the first and the last beyond it).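

In this assay, for the compounds shown here, the group on the nitrogen now shows an effect: 3-chlorophenyl in place of 4-methylphenyl gives a number 12.6 percentage points higher from compound 2 to compound 3 (beyond the scatter), the first such step, with inhibition still small. Exchanging the whole group on the aromatic carbon gives a number 8.7 percentage points higher from compound 1 to compound 3 (within the scatter), so (3-chlorophenyl)amino and 4-methylpiperidin-1-yl remain unseparated. No measured finding explains the step on the nitrogen.

From the compounds shown here alone, whether the chlorine itself or its place on the phenyl ring carries the step stays open. Also open, going by these compounds, is how a methoxy group or a nitrile on that ring would read in this assay.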